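This account rests on a few compounds, and the source may have more. Where it says the series, first, only, none or still open, it means among the compounds named here.

Two measured compounds share one core and differ only in the group at the end of a short chain. Compound 1 `COc1cccc(Oc2c(NS(=O)(=O)c3ccc(C(C)(C)C)cc3)ncnc2OCCOCc2ccccc2)c1` gives 170 nM in an assay on cells (Endothelial cell) for binding affinity to Endothelin-1 receptor (Sus scrofa); on this read-out higher numbers stand for weaker inhibition and lower numbers for stronger inhibition. Compound 2 `COc1cccc(Oc2c(NS(=O)(=O)c3ccc(C(C)(C)C)cc3)ncnc2OCCOc2nccc(C)n2)c1`, which carries a 4-methylpyrimidin-2-yl in place of the benzyl on that oxygen, gives 39.4 nM in this assay, and the step of a 4.3-fold lower number from compound 1 to compound 2 (0.63 log units; beyond the scatter) shows that the exchange brought a clear gain. Compound 2 thus has the lowest of the two numbers seen so far.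

Compound 3 `COc1cccc(Oc2c(NS(=O)(=O)c3ccc(C(C)(C)C)cc3)ncnc2SCCOc2ncccn2)c1` is not yet measured. It differs from compound 2 in (2-((pyrimidin-2-yl)oxy)ethyl)sulfanyl in place of 2-((4-methylpyrimidin-2-yl)oxy)ethoxy on an aromatic carbon. Among the compounds with values here, the one measured step concerned the group at the far end of the chain; no measured step covers an exchange of the atom that ties the chain to the core or the loss of the methyl on the pyrimidine. With nothing to point either way, a step of a 1.5-fold higher number from compound 2 to compound 3 (0.18 log units; within the scatter) is expected, and compound 3 is estimated at 60 nM, within the range 20 nM to 180 nM.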

Compound 3, half-maximal inhibitory concentration: 25.8 nM
Beside the measured number, compound 3's estimate is 2.3-fold (0.37 log units) above it; the range from low to high includes it.
By their numbers in this assay, from the lowest: compounds 3 and 2 (each within the scatter of the next); then compound 1.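

In this assay, the exchange gives a 1.5-fold lower number from compound 2 to compound 3 (0.18 log units; within the scatter), so the sulfur-linked chain without the methyl on the pyrimidine cannot be told apart from the oxygen-linked chain that carries it. Set against the chain ending in benzyl, the new chain gives a 6.6-fold lower number from compound 1 to compound 3 (0.82 log units; beyond the scatter), so two pyrimidine-ended chains now stand clear of 2-(benzyloxy)ethoxy, not just one. No outside evidence bears on why the numbers fall this way.

From the compounds shown here alone, the sulfur and the missing methyl changed together, so each one's separate effect stays unknown, and two opposing effects could hide behind this small net step. Also open, going by these compounds, is whether an amine nitrogen in place of the sulfur, or a longer chain leading to the pyrimidine, would keep numbers like these.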